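Methyl in Place of Methoxy on an Alkynyl Nucleoside

A few compounds are considered here, and "the series" means these few. Any claim that something is new, unique, unknown or untested is made for them only; others in the source may bear on it.

Compound 1 `CC1(C)[C@@H](Cn2cnc3c(Cl)nc(N)nc32)CC[C@@]1(C)CO`: 50000 nM
Compound 2 `O=C1O/C(=C\Cn2ccc(=O)[nH]c2=O)C(Cc2ccccc2)=C1O`: > 200000 nM
Compound 3 `COCC#Cc1cn([C@H]2C[C@H](O)[C@@H](CO)O2)c(=O)[nH]c1=O`: > 200000 nM

In an ADME assay on L1210/0 cells (Mus musculus) for cytotoxicity, with a stated time of 48 h (a lower number here means a stronger inhibitor, a higher number a weaker inhibitor), compound 1 gives 50000 nM. Compound 2 returns only a limit of the assay, > 200000 nM. Compound 3 likewise returns only a limit, > 200000 nM. Compound 3 therefore stands at the limit of > 200000 nM in this assay, at which 2 of the 3 values shown sit, with no number of its own.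

Compound 4 `CCC#Cc1cn([C@H]2C[C@H](O)[C@@H](CO)O2)c(=O)[nH]c1=O` differs from compound 3 by methyl in place of methoxy on a saturated chain carbon bound to a triple-bonded carbon. Among the compounds with values here, no step between two measured compounds is available, so the change can be judged only from where compound 3 sits. The expected step is a number no higher from compound 3 to compound 4 (the limit leaves the size open), none beyond the scatter. Compound 4 is estimated at 200000 nM, within 50000 nM to 1000000 nM, and is expected most likely to return only a limit again.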

Compound 4, half-maximal inhibitory concentration: > 200000 nM
Compound 4: only a limit was reported; the forecaster's own chance of this, stated with the estimate: 80%; the middle value lies on the limit itself.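

Like compound 3, compound 4 returns only a limit in this assay (> 200000 nM), so the step between the two cannot be read. From the compounds shown here alone, whether methyl in place of methoxy shifts the read-out at all remains open.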